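This account rests on a few compounds, and the source may have more. Where it says the series, first, only, none or still open, it means among the compounds named here.

Compound 1 `O=C(/C=C/c1ccccc1F)Nc1ccc(CC2=CC(=O)OC2)cc1`: 11.7%
Compound 2 `C=C1OC(=O)C=C1Cc1ccc(NC(=O)/C=C/c2ccccc2)cc1`: 48.6%

In an assay on isolated protein for inhibition of DNA topoisomerase 1 (Homo sapiens), with a stated time of 30 min, tested at 100 uM (on this read-out higher numbers stand for more inhibition at the one concentration tested (going by the name of the read-out) and lower numbers for less inhibition), compound 2 stands highest of the two numbers; compound 1 lies lower by a gap beyond the usual scatter. Compound 3 `C=C1OC(=O)C=C1Cc1ccc(NC(=O)c2ccccc2)cc1` is still to be measured in this assay. It differs from compound 2 in one place: phenyl in place of 2-phenylethenyl on a carbonyl carbon. Among the compounds with values here, no step between measured compounds covers such a change, so the expectation rests on the value of compound 2 alone. A modest fall is expected, with a number 18.6 percentage points lower from compound 2 to compound 3 (beyond the scatter). Compound 3 is estimated at 30%, within a range from 10% to 55%.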

Compound 3, a percentage reported as inhibition, at one concentration (the size of the read-out at that concentration, not a potency): 28.7%
The estimate for compound 3 lay 1.3 percentage points above the measured number, within the range that was stated.
By their numbers in this assay, from the lowest: compound 1; then compound 3; then compound 2.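

In this assay putting phenyl in place of 2-phenylethenyl on the carbonyl carbon gives a number 19.9 percentage points lower from compound 2 to compound 3 (beyond the scatter) and so shows that the group at this position affects the read-out. Inhibition does not vanish with the double bond outside the aromatic ring gone, so phenyl keeps part of it. Nothing measured here explains the fall.

Going by these compounds, what stays open is whether 2-phenylethyl, the same chain without its double bond, would stand nearer compound 2 or compound 3. On these data alone, how a carboxylic acid or an amine would fare on this carbonyl carbon's substituent is also open.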